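Difluoromethyl for Trifluoromethyl: Solubility in Two Cores

The compounds below may be only part of what the source reports. "The series", "measured", "known", "first", "only" and "open" are said of these compounds alone.

Measured compounds:
compound 1 `C[C@@H]1CN(c2c(C#N)c(C(F)(F)F)nn2-c2ccc(S(C)(=O)=O)cn2)[C@H](C)CO1` — > 200 ug/mL
compound 2 `C[C@@H]1CN(c2c(C#N)c(C(F)F)nn2-c2ccc(S(C)(=O)=O)cn2)[C@H](C)CO1` — > 200 ug/mL
compound 3 `CS(=O)(=O)c1ccc(-n2nc(C(F)(F)F)c(C#N)c2NCC2CC2)cc1` — "not determined" (no result reported)

In a physicochemical assay for solubility (on this read-out lower numbers stand for lower solubility and higher numbers for higher solubility), compound 1 gives > 200 ug/mL, which is a limit of the assay rather than a number. Compound 2 likewise gives > 200 ug/mL in this assay, again a limit. The change between them is hydrogen in place of fluoro on a saturated chain carbon bound to an aromatic carbon and two fluorine atoms, and it gives a step that the two limits leave unreadable from compound 1 to compound 2, because both values sit at the limit of > 200 ug/mL in this assay, at which 2 of the 3 values shown sit. In this assay compound 3 gives "not determined" (no result reported). The difference between the core of compound 1 and the core of compound 3 is not broken down here. Compound 4 `CS(=O)(=O)c1ccc(-n2nc(C(F)F)c(C#N)c2NCC2CC2)cc1` differs from compound 3 by hydrogen in place of fluoro on a saturated chain carbon bound to an aromatic carbon and two fluorine atoms, the same change at the same place. Compound 4 is expected to give about 150 ug/mL in this assay, between 30 ug/mL and 400 ug/mL. This expectation rests on compound 1 and compound 2 both sitting at the limit of > 200 ug/mL in this assay, at which 2 of the 3 values shown sit, while no value for compound 3 anchors the new core.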

Compound 4, solubility: > 200 ug/mL
Compound 4 was reported as a limit (the forecaster's own chance of this, stated with the estimate: 40%); middle value at least 1.3-fold (0.12 log units) from the limit.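

Compound 4 gives > 200 ug/mL in this assay, which is a limit of the assay. Compound 3 gives "not determined" (no result reported), so no step can be read between compound 3 and compound 4. As far as these compounds go, whether trifluoromethyl to difluoromethyl changes solubility in either core stays open.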